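The source may hold more compounds than are shown below. What is called first, only, known or untested is meant among the compounds shown, and "the series" means these compounds.

Going by the values given here, compound 3, with structure `Cc1n[nH]cc1CN[C@@H]1C[C@H]2C[C@@H]([C@H]1C)C2(C)C`, is one of three compounds measured in an ADME assay on MDCK cells (Canis lupus familiaris) for cytotoxicity, read by microscopy, with a stated time of 48 h; on this read-out higher numbers stand for lower toxicity in this test and lower numbers for higher toxicity in this test. For compound 3 the assay gives only a limit, > 100000 nM, not a number. Compound 2, with structure `C[C@H]1[C@H](NCc2cncs2)C[C@H]2C[C@@H]1C2(C)C`, also sits at a limit in this assay, > 100000 nM. Compound 1, with structure `Cc1ccsc1CN[C@@H]1C[C@H]2C[C@@H]([C@H]1C)C2(C)C`, gives a number in this assay, 10000 nM. The steps of an at least 10-fold higher number from compound 1 to compound 2 (1.00 log units; beyond the scatter) and an at least 10-fold higher number from compound 1 to compound 3 (1.00 log units; beyond the scatter) both run upward, towards lower toxicity, while the step that the two limits leave unreadable from compound 2 to compound 3 cannot be read, because of the limit of > 100000 nM in this assay, at which 2 of the 3 values shown sit.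

Compound 4, with structure `C[C@H]1[C@H](NCc2nccs2)C[C@H]2C[C@@H]1C2(C)C`, differs from compound 3 in one place: 1,3-thiazol-2-yl in place of 3-methyl-1H-pyrazol-4-yl on a saturated chain carbon bound to an amine nitrogen. The closest measured guide is compound 2, which carries a related five-membered ring with two hetero atoms and reaches the limit. Since compound 3 also stands at that limit, no step can be read from it, and the expectation for compound 4 is a value at or near the same limit, with no step beyond the scatter. Compound 4 is therefore expected to give 100000 nM, between 30000 nM and 300000 nM, which means an estimated step of a number no higher from compound 3 to compound 4 (the limit leaves the size open) in this assay.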

Compound 4, minimum cytotoxic concentration: > 100000 nM
Compound 4 ended at the assay's limit (the forecaster's own chance of this, stated with the estimate: 70%); the middle value sits exactly at the limit.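

In this assay, the 1,3-thiazol-2-yl group of compound 4 gives the third clear contrast with the 3-methylthiophen-2-yl group on the saturated chain carbon bound to an amine nitrogen, with an at least 10-fold higher number from compound 1 to compound 4 (1.00 log units; beyond the scatter) as the step. Among the compounds shown, every five-membered aromatic ring with 2 hetero atoms now stands apart from compound 1 in the same direction, and no compound goes against this. The result holds for both thiazole groups, which have 0 hydrogen-bond donors, and for the 3-methyl-1H-pyrazol-4-yl group, which has 1, although the steps among compound 2, compound 3 and compound 4 cannot be read because all three stop at the same limit: the limit of > 100000 nM in this assay, at which 3 of the 4 values shown sit.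

Going by these compounds, how far these three compounds differ from one another therefore stays open. On these data alone, it is also open whether the lower number of compound 1 goes with its methyl group or with the thiophene ring itself, a question on which a plain thiophen-2-yl or a phenyl ring at the same place would bear.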